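Swapping the Furan for a Hydroxyphenyl Ring

The source may hold more compounds than are shown below. What is called first, only, known or untested is meant among the compounds shown, and "the series" means these compounds.

Compound 1 `O=C(/C=C/c1ccc2c(c1)B(O)OC2)c1ccco1` is the point of departure. In a toxicity assay on MCF-10A cells (Homo sapiens) for cytotoxicity, read by MTT assay, with a stated time of 48 h (a higher number here means a weaker inhibitor, a lower number a stronger inhibitor), compound 1 gives 7400 nM, the lowest of the three numbers recorded so far. Its two measured neighbours sit higher: compound 2 `O=C(/C=C/c1ccc2c(c1)B(O)OC2)c1cccnc1` gives 34400 nM, and compound 3 `O=C(/C=C/c1ccc2c(c1)B(O)OC2)c1ccccc1F` gives 25400 nM. Both neighbours alter only the group on the carbonyl carbon, and both moves raise the number beyond the scatter: a 4.6-fold higher number from compound 1 to compound 2 (0.67 log units; beyond the scatter) and a 3.4-fold higher number from compound 1 to compound 3 (0.54 log units; beyond the scatter). The gap between the two, a 1.4-fold lower number from compound 2 to compound 3 (0.13 log units; within the scatter), stays within the scatter, so the two six-membered aromatic rings behave alike here.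

Compound 4 `O=C(/C=C/c1ccc2c(c1)B(O)OC2)c1cccc(O)c1` makes a change of the same kind: 3-hydroxyphenyl in place of furan-2-yl on a carbonyl carbon. As with compounds 2 and 3, a five-membered aromatic ring gives way to a six-membered one, and the 3-hydroxyphenyl brings 1 hydrogen-bond donor that neither measured neighbour carried. Going by the values given here, the two relevant steps were modest and pointed the same way, so a modest rise beyond the scatter is the natural expectation in this assay, though no measured compound shows how the hydrogen-bond donor itself is received. Compound 4 is therefore expected to give 22000 nM, with a range from 9000 nM to 50000 nM, which corresponds to an expected step of a 3.0-fold higher number from compound 1 to compound 4 (0.47 log units; beyond the scatter).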

Compound 4, half-maximal inhibitory concentration: 25300 nM
Estimate against measurement, compound 4: 1.2-fold (0.06 log units) below; the measured number falls inside the stated range.
By their numbers in this assay, from the lowest: compound 1; then compounds 4, 3 and 2 (each within the scatter of the next).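

In this assay, 3-hydroxyphenyl in place of furan-2-yl on the carbonyl carbon gives a 3.4-fold higher number from compound 1 to compound 4 (0.53 log units; beyond the scatter) and so places a third six-membered aromatic ring above compound 1, alongside compounds 2 and 3. The hydrogen-bond donor of 3-hydroxyphenyl, which neither 2-fluorophenyl nor pyridin-3-yl carries, leaves no mark that can be read, with a 1.0-fold lower number from compound 3 to compound 4 (0.00 log units; within the scatter) and with a 1.4-fold lower number from compound 2 to compound 4 (0.13 log units; within the scatter) in the comparison with the two earlier rings. Among these four compounds, furan-2-yl alone stands apart at this position, while the three six-membered rings lie within the scatter of one another, and no measurement at hand accounts for this.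

With furan-2-yl the only five-membered ring shown, it remains open whether a thiophene ring or a pyrrole ring would keep the number of compound 1, and whether an unsubstituted phenyl would sit with compounds 2, 3 and 4. Going by these compounds, it also remains open whether an amine or a carboxylic acid on the six-membered ring would shift the number beyond the scatter, or whether the ring would stay as insensitive to such a group as it has been so far.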